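Pyrazole amides: an aromatic ring gives way to cyclopentylmethyl

A few compounds are considered here, and "the series" means these few. Any claim that something is new, unique, unknown or untested is made for them only; others in the source may bear on it.

Of the compounds shown here, two have been measured in an assay on HEK293 cells for displacement of a labelled ligand from metabotropic glutamate receptor 5 (Rattus norvegicus); a higher number here means a weaker inhibitor, a lower number a stronger inhibitor. Compound 1 `O=C(Nc1cc(-c2ccccc2)nn1-c1ccccc1)c1cccc([N+](=O)[O-])c1` gives 2220 nM. Compound 2 `Cc1ccc(C(=O)Nc2cc(-c3ccccc3)nn2-c2ccccc2)cn1` gives 3480 nM; of the two numbers it is the higher, but the step of a 1.6-fold higher number from compound 1 to compound 2 (0.20 log units; within the scatter) lies within the scatter, so the two compounds cannot be told apart on these data. That step exchanges one aromatic ring for another on the carbonyl carbon.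

Compound 3 `O=C(CC1CCCC1)Nc1cc(-c2ccccc2)nn1-c1ccccc1` has not been measured. It differs from compound 2 in one place: cyclopentylmethyl in place of 6-methylpyridin-3-yl on a carbonyl carbon. Here an aromatic ring with a nitrogen leaves and a saturated ring on a one-carbon link enters. Going by the values given here, no measured step bears on this kind of change; the only step known swaps two aromatic rings and gives no guidance on replacing an aromatic ring by a saturated one. The expectation therefore rests on compound 2 alone, and a step of a 1.7-fold higher number from compound 2 to compound 3 (0.24 log units; within the scatter) is expected, with wide uncertainty and no firm direction. Compound 3 is thus estimated at 6000 nM, within a range from 2000 nM to 20000 nM.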

Compound 3, inhibition constant: > 10000 nM
Compound 3 was reported as a limit; the forecaster's own chance of this, stated with the estimate: 25%; at least 1.6-fold (0.22 log units) between middle value and limit.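

In this assay compound 3 is reported only as a limit, > 10000 nM, and not as a number. Even so, the steps to it can be read as minimum sizes: cyclopentylmethyl on the carbonyl carbon gives an at least 2.8-fold higher number from compound 2 to compound 3 (0.45 log units; beyond the scatter), and measured against the 3-nitrophenyl group it gives an at least 4.5-fold higher number from compound 1 to compound 3 (0.65 log units; beyond the scatter), so this position, where exchanging one aromatic ring for another gave only a 1.6-fold higher number from compound 1 to compound 2 (0.20 log units; within the scatter), does respond to a change of group, and leaving the aromatic rings for this saturated ring weakens binding. How large the loss really is cannot be said, because the value for compound 3 marks only where the readout stops: the limit of > 10000 nM in this assay, at which 1 of the 3 values shown sits.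

The compounds shown leave open whether the loss goes with the saturated ring itself or with the one-carbon link that carries it, and a cyclopentyl group set directly on the carbonyl carbon would separate the two. They also leave open whether any non-aromatic group is tolerated here, for instance a short unbranched alkyl chain or a ring holding an amine.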